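The compounds below may be only part of what the source reports. "The series", "measured", "known", "first", "only" and "open" are said of these compounds alone.

Measured compounds:
compound 1 `CCOC(=O)/C=C/c1cccc(OCc2nc(C)c(C)nc2C)c1` — 628000 nM
compound 2 `CCOC(=O)/C=C/c1ccccc1OCc1nc(C)c(C)nc1C` — 502000 nM
compound 3 `Cc1nc(C)c(COc2cccc(/C=C/C(=O)O)c2)nc1C` — 161000 nM

All values come from a functional assay on a cell-free system (Platelet, plasma, Oryctolagus cuniculus) for inhibition, with a stated time of 5 min; on this read-out lower numbers stand for stronger inhibition and higher numbers for weaker inhibition. Compound 1 and compound 3 differ by hydrogen in place of ethyl on an oxygen next to a carbonyl group, and the step is a 3.9-fold lower number from compound 1 to compound 3 (0.59 log units; beyond the scatter). Compound 2 has the same atoms as compound 1 joined differently; the difference between the two cores is not broken down here, and the values of compound 1 and compound 2 lie within the usual scatter of each other. Compound 4 `Cc1nc(C)c(COc2ccccc2/C=C/C(=O)O)nc1C` has not yet been measured in this assay; it differs from compound 2 by hydrogen in place of ethyl on an oxygen next to a carbonyl group, the same change as that from compound 1 to compound 3, occurring twice in this set. For the measured compounds named here, the expected step is a 3.6-fold lower number from compound 2 to compound 4 (0.55 log units; beyond the scatter), resting only on the single earlier step of a 3.9-fold lower number from compound 1 to compound 3 (0.59 log units; beyond the scatter). Compound 4 is estimated at 140000 nM, with an expected range from 60000 nM to 350000 nM.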

Compound 4, half-maximal inhibitory concentration: 54000 nM
Estimate against measurement, compound 4: 2.6-fold (0.41 log units) above; measured number outside the range, below it.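

In this assay, the change from ethoxycarbonyl to carboxy on the core of compound 2 gives a 9.3-fold lower number from compound 2 to compound 4 (0.97 log units; beyond the scatter), in the same direction as on the core of compound 1. The two steps cannot be told apart: the same change on two cores in this assay, a 3.9-fold lower number (0.59 log units; beyond the scatter) from compound 1 to compound 3 and a 9.3-fold lower number (0.97 log units; beyond the scatter) from compound 2 to compound 4, 2.4-fold (0.38 log units) apart, within the scatter of two such steps

The change therefore carries across these two cores in direction and in roughly its size, but this does not show that it is worth more on one core than on the other, and two pairs set no rule for any further core. Open, as far as these compounds go, is whether a primary amide or a tetrazole in place of the carboxy group would give a similar step. Also open, from the compounds shown here alone, is what a saturated propanoic acid chain would do in place of 2-carboxyethenyl.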